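Compound 1 to compound 3: a step at the limit

This account rests on a few compounds, and the source may have more. Where it says the series, first, only, none or still open, it means among the compounds named here.

Compound 1 `Cc1cc(NC(=O)Nc2ccccc2N)c2ccccc2n1` stands only at a limit on the numbers shown. In an ADME assay on HEK293 cells (Homo sapiens) for cytotoxicity, with a stated time of 72 h (on this read-out higher numbers stand for an effect only at larger amounts of compound and lower numbers for an effect already at smaller amounts), compound 1 gives > 25000 nM as a limit and not a number. Compound 2 `Cc1cc(NC(=O)Nc2ccccc2C(C)(C)C)c2ccccc2n1` gives > 25000 nM as a limit too. Among the measured compounds shown here, the one measured step is a step that the two limits leave unreadable from compound 1 to compound 2 and offers no size to carry over, with tert-butyl in place of amino on an aromatic carbon. The record so far is the limit of > 25000 nM in this assay, at which 2 of the 2 values shown sit, and holds no readable number.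

Compound 3 `Cc1cc(NC(=O)Nc2cccc(F)c2)c2ccccc2n1` has 3-fluorophenyl in place of 2-aminophenyl on an amide-type nitrogen, and the counted change is 3-fluorophenyl in place of 2-aminophenyl on an amide-type nitrogen on the shared core. Another reading near the limit is expected in this assay because the limit of > 25000 nM in this assay, at which 2 of the 2 values shown sit, holds for compound 1 and compound 2 alike, so no step beyond the scatter is anticipated in either direction. The estimated change is a number no higher from compound 1 to compound 3 (the limit leaves the size open). Compound 3 is estimated at 25000 nM with an expected range from 10000 nM to 50000 nM and will most likely be reported as a limit again.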

Compound 3, half-maximal effective concentration: > 25000 nM
Compound 3 was reported as a limit (the forecaster's own chance of this, stated with the estimate: 80%); the middle value sits exactly at the limit.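

Compound 3 joins compound 1 and compound 2 at a limit and not a number, so the steps from compound 1 to each of the other two cannot be read in this assay: the limit of > 25000 nM in this assay, at which 3 of the 3 values shown sit. The compounds shown leave open how far each lies past that limit, and whether any change on the shared core gives a readable half-maximal effective concentration.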